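The source may report more compounds than this note shows. Statements on the series, on what has been measured and on what is new or still open speak of the compounds shown alone.

Compound 1 `COc1cc2ncnc(N3CCC(CN4CCN(c5cccc(Cl)c5)CC4)C3)c2cc1OC`; compound 2 `COc1cc2ncnc(N3CCC(CN4CCN(c5ccc(O)cc5)CC4)C3)c2cc1OC`.

In an assay on membranes from CHO-K1 cells for displacement of a labelled ligand from 5-hydroxytryptamine receptor 7 (Homo sapiens), read by scintillation counting (on this read-out lower numbers stand for stronger inhibition and higher numbers for weaker inhibition), compound 1 gives 372 nM. In this assay compound 2 reaches only > 1000 nM, which is a limit of the assay and not a number (the limit of > 1000 nM in this assay, at which 1 of the 2 values shown sits). The step of an at least 2.6-fold higher number from compound 1 to compound 2 (0.42 log units; beyond the scatter) therefore weakened binding, and compound 2 stands at the weak end of what has been measured. Compound 3 `COc1cc2ncnc(N3CCC(CN4CCN(c5ccccn5)CC4)C3)c2cc1OC` carries pyridin-2-yl in place of 4-hydroxyphenyl on an amine nitrogen in a ring. Within the data shown here, only that single measured step bears on this change, and it leaves the position of compound 2 open as a limit. The expected step for compound 3 is an at least 1.2-fold lower number from compound 2 to compound 3 (0.09 log units; that floor lies within the scatter). For compound 3 the estimated value is 800 nM, within 250 nM to 3000 nM.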

Compound 3, inhibition constant: 282 nM
Beside the measured number, compound 3's estimate is 2.8-fold (0.45 log units) above it; low and high end bracket the measured number.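

In this assay the weak binding of compound 2 does not extend to every aromatic group at this amine nitrogen: pyridin-2-yl in place of 4-hydroxyphenyl gives an at least 3.5-fold lower number from compound 2 to compound 3 (0.54 log units; beyond the scatter). Against 3-chlorophenyl the same group gives a 1.3-fold lower number from compound 1 to compound 3 (0.12 log units; within the scatter), so the two are not told apart here, and only 4-hydroxyphenyl stands apart. Compound 2 stands at a limit of the assay and not a number, so its step is only a floor: the limit of > 1000 nM in this assay, at which 1 of the 3 values shown sits.

The compounds shown leave open how an unsubstituted phenyl or a pyrimidin-2-yl group would read at this position. They also leave open whether the hydroxyl of compound 2 alone accounts for its weak binding.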